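The source may hold more compounds than are shown below. What is called first, only, known or untested is meant among the compounds shown, and "the series" means these compounds.

Compound 1, `CCC(C(=O)N1CCN(c2ccccc2Cl)CC1)N1C(=O)CCC1=O`, gives 25% in a functional assay on the whole organism (strain Swiss) with Mus musculus as the target, in the maximal electroshock model, with a stated time of 0.5 h, at a dose of 300 mg/kg by the intraperitoneal route; a higher number here means a stronger effect of the compound at the dose given, a lower number a weaker effect. Compound 3, `CCC(C(=O)N1CCN(c2ccccc2C(F)(F)F)CC1)N1C(=O)CCC1=O`, gives 25% in this assay, level with compound 1 within the scatter; together they are the lowest of the three numbers, while compound 2, `CC(C(=O)N1CCN(c2ccccc2C(F)(F)F)CC1)N1C(=O)CCC1=O`, gives 100%. Compound 4, `CCC(C(=O)N1CCN(c2cccc(C)c2)CC1)N1C(=O)CCC1=O`, differs from compound 1 in one place: 3-methylphenyl in place of 2-chlorophenyl on an amine nitrogen in a ring. Going by the values given here, the one measured step that bears on this also exchanges the group on the ring nitrogen, and it gave no change at the digits printed from compound 1 to compound 3 (within the scatter). The other step, a number 75 percentage points lower from compound 2 to compound 3 (beyond the scatter), concerns the saturated chain carbon and not the group on the ring nitrogen. A step of no change at the digits printed from compound 1 to compound 4 (within the scatter) is therefore expected, none beyond the scatter. Compound 4 is expected to give about 25%, within a range from 0% to 50%.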

Compound 4, a percentage reported as activity, at one dose (the size of the read-out at that dose, not a potency): 100%
The estimate for compound 4 lay 75 percentage points below the measured number; measured number above the stated range.
By their numbers in this assay, from the lowest: compounds 1 and 3 (each within the scatter of the next); then compounds 2 and 4 (each within the scatter of the next).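

In this assay, 3-methylphenyl in place of 2-chlorophenyl on the ring nitrogen gives a number 75 percentage points higher from compound 1 to compound 4 (beyond the scatter), whereas the earlier exchange at this nitrogen gave no change at the digits printed from compound 1 to compound 3 (within the scatter). The group at this position can therefore matter a great deal, even with the rest of compound 1 unchanged. No measurement shown explains this step. This change replaces chloro with methyl and also alters where the group sits on the phenyl ring, and the compounds shown do not separate the two. Going by these compounds, an unsubstituted phenyl or a methoxyphenyl at this nitrogen remains open.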